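Swapping a Heptyl Chain for Phenyl in an Electroshock Model

The compounds below may be only part of what the source reports. "The series", "measured", "known", "first", "only" and "open" are said of these compounds alone.

Compound 1 `CCCCCCOc1ccc(-n2cnnc2CCCCCC)cc1` gives > 40 mg/kg in a functional assay on the whole organism (strain C57B/6) with Mus musculus as the target, in the maximal electroshock model (a higher number here means that more compound is needed for the effect, a lower number that less compound is needed), and this is a limit of the assay rather than a number.
Compound 2 `CCCCCCCc1nncn1-c1ccc(OCCCCCC)cc1` gives > 40 mg/kg in this assay, again a limit rather than a measured number.

Compound 2 therefore stands only at a limit in this assay, with no dose of its own to compare against. The change to compound 3 `CCCCCCOc1ccc(-n2cnnc2-c2ccccc2)cc1` is phenyl in place of heptyl on an aromatic carbon. Going by the values given here, the only measured step, a step that the two limits leave unreadable from compound 1 to compound 2, bears on it loosely, and its size cannot be read since (the limit of > 40 mg/kg in this assay, at which 2 of the 2 values shown sit). Among the compounds with values here, no step of a readable size can thus be expected in this assay for compound 3, in either direction, and another limit is quite possible. Compound 3 is estimated at 50 mg/kg, with an expected range from 15 mg/kg to 150 mg/kg. That estimate means an expected step that the limit leaves unreadable from compound 2 to compound 3.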

Compound 3, dose for half-maximal effect: 19 mg/kg
Beside the measured number, compound 3's estimate is 2.6-fold (0.42 log units) above it, and the stated range covers the measured number.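

In this assay, the aromatic carbon between two ring nitrogen atoms now yields a readable result: phenyl in place of heptyl gives an at least 2.1-fold lower number from compound 2 to compound 3 (0.32 log units; beyond the scatter), and phenyl in place of hexyl gives an at least 2.1-fold lower number from compound 1 to compound 3 (0.32 log units; beyond the scatter). The two chains had left it unclear whether this position responds to a change at all, and the phenyl ring shows that it does. Each step is only a minimum, because the starting point is not a measured number: the limit of > 40 mg/kg in this assay, at which 2 of the 3 values shown sit.

From the compounds shown here alone, what remains open is whether the ring itself matters or whether a short chain such as propyl would serve as well. The compounds shown also leave untested how a pyridyl ring or a chlorophenyl group would behave at this position, and whether the hexyloxy chain on the other ring can be changed.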